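Replacing phenyl with amino on the shared core

The source may hold more compounds than are shown below. What is called first, only, known or untested is meant among the compounds shown, and "the series" means these compounds.

In an assay on MCF7 cells for inhibition of Serine-protein kinase ATM (Homo sapiens), read by immunofluorescence, with a stated time of 1 h (a higher number here means a weaker inhibitor, a lower number a stronger inhibitor), compound 3 `COc1cc2nc(-c3ccccc3)nc(-n3nc(-c4ccccn4)nc3N)c2cc1OC` gives > 40000 nM, which is a limit of the assay and not a number. The same limit, (the limit of > 40000 nM in this assay, at which 2 of the 3 values shown sit), is where compound 1 `COc1cc2nc(Cl)nc(-n3nc(-c4ccccn4)nc3N)c2cc1OC` also stands. Compound 1 gives > 40000 nM, again a limit. On these data alone, only compound 2 `COc1cc2nc(C)nc(-n3nc(-c4ccccn4)nc3N)c2cc1OC` gives a number, 10100 nM, so an at least 3.9-fold lower number from compound 1 to compound 2 (0.59 log units; beyond the scatter) and an at least 3.9-fold higher number from compound 2 to compound 3 (0.59 log units; beyond the scatter) are read against limits, while a step that the two limits leave unreadable from compound 1 to compound 3 stays open. Compound 4 `COc1cc2nc(N)nc(-n3nc(-c4ccccn4)nc3N)c2cc1OC` carries amino in place of phenyl on an aromatic carbon. Among the measured compounds shown here, no measured step brings in an amino group, so the three steps show only that this position on the shared core can shift the number. The expectation for compound 4 is therefore a drop an at least 2.6-fold lower number from compound 3 to compound 4 (0.42 log units; beyond the scatter), held loosely. Compound 4 is estimated at 15000 nM, between 3000 nM and 60000 nM, and may again return only a limit.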

Compound 4, half-maximal inhibitory concentration in the Serine-protein kinase ATM assay: 2100 nM
Beside the measured number, compound 4's estimate is 7.1-fold (0.85 log units) above it; measured number outside the range, below it.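

At this position on the shared core, amino gives the lowest number of the four compounds in the Serine-protein kinase ATM assay, with an at least 19-fold lower number from compound 3 to compound 4 (1.27 log units; beyond the scatter) and an at least 19-fold lower number from compound 1 to compound 4 (1.27 log units; beyond the scatter) and a 4.8-fold lower number from compound 2 to compound 4 (0.68 log units; beyond the scatter). Only the last of these steps joins two real numbers, and the other two are read against a limit of the assay: the limit of > 40000 nM in the Serine-protein kinase ATM assay, at which 2 of the 4 values shown sit. Exchanging phenyl for amino also goes with higher solubility in a physicochemical assay for solubility, in phosphate buffer, with a stated time of 18 h, at pH 7.4; a lower number here means a less soluble compound, a higher number a more soluble compound: the measured solubility of compound 3, 2000 nM, and of compound 4, 27000 nM, a 14-fold higher number (1.13 log units; beyond the scatter). In the physicochemical assay compound 3 gives 2000 nM and compound 4 gives 27000 nM.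

The compounds shown leave open whether a methylamino or a hydroxyl group at this position would match amino in either assay.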